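The compounds below may be only part of what the source reports. "The series", "measured", "known", "first", "only" and "open" are said of these compounds alone.

Notes on the selenocyanate series

Compound 1 `CCCCOC(=O)Nc1ccc([Se]C#N)cc1` carries a butyl carbamate on the shared core. In a functional assay on HTB-54 cells (Homo sapiens) for cytotoxicity, read by MTT assay, with a stated time of 72 h (on this read-out higher numbers stand for weaker inhibition of growth and lower numbers for stronger inhibition of growth), compound 1 gives 43400 nM, the lower of the two numbers measured. For the measured compounds named here, compound 2 `N#C[Se]c1ccc(NC(=O)OCc2ccc([N+](=O)[O-])cc2)cc1`, the analogue with a nitrobenzyl carbamate in place of the butyl carbamate, gives 47600 nM in this assay; the two values lie within the scatter of each other, so no order can be read between compound 1 and compound 2, and the series so far shows two different carbamates at about the same level.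

Compound 3 `CCOC(=O)Nc1ccc([Se]C#N)cc1` has not been measured. Relative to compound 1 the change is hydrogen in place of ethyl on a saturated chain carbon, two bonds along the chain from an oxygen next to a carbonyl group, shortening the chain of the carbamate without touching the core or the selenocyanate.

Given that the two measured carbamates sit at the same level, the step from compound 1 to compound 3 is expected to stay within the scatter, with at most a slight drift toward weaker inhibition, which is what a 1.2-fold higher number from compound 1 to compound 3 (0.08 log units; within the scatter) means here. For compound 3 the estimate in this assay is 52000 nM, with a range from 22000 nM to 125000 nM.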

Compound 3, concentration for total growth inhibition: 49300 nM
For compound 3 the middle estimate is 1.1-fold (0.02 log units) above the measured one, and the stated range covers the measured number.
By their numbers in this assay, from the lowest: compounds 1, 2 and 3 (each within the scatter of the next).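

Working from the butyl carbamate to the ethyl carbamate gives a 1.1-fold higher number from compound 1 to compound 3 (0.06 log units; within the scatter) in this assay, and this is the first step in the series that changes only one place, hydrogen in place of ethyl on a saturated chain carbon, two bonds along the chain from an oxygen next to a carbonyl group. For the compounds shown here, it shows that this ethyl can leave the chain without the number moving beyond the scatter, so at this position the read-out does not separate the butyl carbamate from the ethyl carbamate, whereas the earlier pair of compounds offered no single-place step to read. Nothing available on these compounds bears on why the change leaves the number where it is.

This single step covers one removal of two carbons and gives no trend along the chain, so it cannot say how far the tolerance extends. Going by these compounds, a longer chain such as octyl, or an amine or a carboxylic acid in place of the ethyl, remains open, as does whether any such group would move the number beyond the scatter.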